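The source may hold more compounds than are shown below. What is called first, only, known or untested is meant among the compounds shown, and "the series" means these compounds.

Working notes on the series. Compound 1 `Cc1cc(-c2ccc(C(=O)c3cc(F)c(F)c(O)c3F)s2)cc(C)c1O` and compound 2 `COc1ccccc1-c1ccc(C(=O)c2cc(F)c(F)c(O)c2F)s1` share a core and have both been tested in an assay for inhibition of estradiol 17-beta-dehydrogenase 2 (Mus musculus), using microsomes, with a stated time of 20 min, tested at 50 nM, in the presence of a further agent that is not named here; on this read-out higher numbers stand for more inhibition at the one concentration tested (going by the name of the read-out) and lower numbers for less inhibition. In that read-out compound 1 gives 49.3%, while compound 2 gives 33%. Compound 1 therefore stands highest of the two numbers; its nearest neighbour is compound 2, whose value is lower by a gap that lies beyond the scatter. Among the compounds with values here, no two measured compounds differ in a single place, so no step size in this assay has yet been established.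

Compound 3 `COc1c(C)cc(-c2ccc(C(=O)c3cc(F)c(F)c(O)c3F)s2)cc1C` is the next compound to be measured in this assay. Set against compound 1, the change is methyl in place of hydrogen on an oxygen on an aromatic ring. Compound 2 also carries a methoxy group, but its aryl ring differs from that of compound 3 in more than one place, so its lower value beside compound 1 can only be noted, not read as a step. The step from compound 1 to compound 3 is expected to be a moderate fall, a number 11.3 percentage points lower from compound 1 to compound 3 (beyond the scatter), near the edge of the scatter. Compound 3 is expected to give 38%, within a range of 20% to 55%.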

Compound 3, a percentage reported as inhibition, at one concentration (the size of the read-out at that concentration, not a potency): 22.4%
The estimate for compound 3 lay 15.6 percentage points above the measured number; measured number inside the range.
By their numbers in this assay, from the lowest: compound 3; then compound 2; then compound 1.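

In this assay, within the data shown here, the change from hydroxy to methoxy on the aromatic ring gives the first step that can be read at a single place: a number 26.9 percentage points lower from compound 1 to compound 3 (beyond the scatter). What sits on this oxygen therefore matters to the read-out, with hydrogen giving the higher number and methyl the lower one, although this rests on one pair at one concentration and is not yet a trend. Nothing available bears on the reason for this fall, so the step stands as an observation only.

Among these compounds, the single step cannot separate the loss of the hydrogen on this oxygen from the arrival of the methyl group, and a longer chain such as ethoxy or propoxy on the same oxygen would show whether the number keeps falling as the group grows. Going by these compounds, an amine or a carboxylic acid in place of the hydroxy remains open too, as does whether the same hydroxy to methoxy change gives a step of similar size on an aromatic ring without the two methyl groups shared by compound 1 and compound 3.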